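Dimethoxy substitution on the ring nitrogen of compound 2

This account rests on a few compounds, and the source may have more. Where it says the series, first, only, none or still open, it means among the compounds named here.

Three measured compounds frame the question. Compound 1 `COc1ccccc1N1C(=O)CSC1C(=O)NCCCCc1ccccc1` gives 0% in a functional assay on HOS-TE85 cells (Homo sapiens) for inhibition, read by CCK-8 assay, with a stated time of 72 h, tested at 1 uM; a higher number here means more inhibition at the concentration tested (going by the name of the read-out), a lower number less inhibition. Compound 2 `O=C(NCCCCc1ccccc1)c1cccc(C2SCC(=O)N2c2ccccc2)c1` gives 96% in this assay, the highest of the three numbers; compound 3 `O=C(NCCCCc1ccccc1)c1cccc(C2OCC(=O)N2c2cccc(F)c2)c1` gives 87%, a value within the scatter of compound 2, while compound 1 lies far below both. Compound 4 `COc1ccc(N2C(=O)CSC2c2cccc(C(=O)NCCCCc3ccccc3)c2)c(OC)c1` has not yet been tested. It differs from compound 2 in one place: 2,4-dimethoxyphenyl in place of phenyl on an amide-type nitrogen in a ring. Within the data shown here, no measured pair shows the effect of this change, so the step can only be judged from the spread of the three values, where compound 3 shows that a substituted phenyl on that nitrogen keeps a high number. A modest loss, at the edge of the scatter, is expected from compound 2 to compound 4, a number 18 percentage points lower from compound 2 to compound 4 (beyond the scatter). Compound 4 is therefore estimated to give 78% in this assay, with a range from 40% to 97%.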

Compound 4, a percentage reported as inhibition, at one concentration (the size of the read-out at that concentration, not a potency): 58%
Beside the measured number, compound 4's estimate is 20 percentage points above it, within the range that was stated.
By their numbers in this assay, from the lowest: compound 1; then compound 4; then compounds 3 and 2 (each within the scatter of the next).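

In this assay, among these compounds, 2,4-dimethoxyphenyl in place of phenyl on the amide-type nitrogen in the ring gives a number 38 percentage points lower from compound 2 to compound 4 (beyond the scatter), which is the first direct reading of a change at this position, and a large one. The group on this nitrogen therefore matters to the read-out, since this single change is enough to move the number well outside the usual scatter. The loss is only partial, however, as compound 4 still gives 58% at the concentration tested. Nothing available here explains why the number falls with this change. As far as these compounds go, it remains open which of the two methoxy groups accounts for the loss, and how an amine or a carboxylic acid on that phenyl would read in this assay.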